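This account rests on a few compounds, and the source may have more. Where it says the series, first, only, none or still open, it means among the compounds named here.

Measured compounds:
- compound 1, `COc1cc(-c2cc3nccc(-c4c[nH]c5ccccc45)n3n2)cc(OC)c1OC`: > 10000 nM in a functional assay on HCT-116 cells (Homo sapiens) for inhibition, read by CCK-8 assay, with a stated time of 48 h; a higher number here means a weaker inhibitor, a lower number a stronger inhibitor
- compound 2, `COc1cc(-c2ccnc3cc(-c4ccc5c(ccn5C)c4)nn23)cc(OC)c1OC`: 39 nM

Compound 1 gives only a limit in this assay, > 10000 nM, and no number. Going by the values given here, compound 2 gives the only number in the set, 39 nM. Because the value of compound 1 is a limit (the limit of > 10000 nM in this assay, at which 1 of the 2 values shown sits), compound 2 cannot be ranked against compound 1 beyond the fact that one gives a number and the other does not. Among the compounds with values here, no step between measured compounds that differ in one place is available.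

Compound 3, `COc1cc(-c2ccnc3cc(-c4ccc5cnn(C)c5c4)nn23)cc(OC)c1OC`, is not yet measured. It differs from compound 2 in one place: 1-methyl-1H-indazol-6-yl in place of 1-methyl-1H-indol-5-yl on an aromatic carbon. Both the leaving and the entering group are fused two-ring aromatics of the same heavy-atom count, so a large shift is not expected; a small loss, or none beyond the scatter, is the expectation. Compound 3 is estimated at 80 nM, within 20 nM to 400 nM, which means an expected step of a 2.1-fold higher number from compound 2 to compound 3 (0.31 log units; beyond the scatter).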

Compound 3, half-maximal inhibitory concentration: 2440 nM
For compound 3 the middle estimate is 31-fold (1.48 log units) below the measured one, outside the stated range (above it).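

In this assay, 1-methyl-1H-indazol-6-yl in place of 1-methyl-1H-indol-5-yl on an aromatic carbon gives a 63-fold higher number from compound 2 to compound 3 (1.80 log units; beyond the scatter), so this place on the five-membered aromatic ring with 2 nitrogen distinguishes sharply between two fused two-ring aromatics with equal heavy-atom counts and no hydrogen-bond donors. The change alters both the hetero atoms in the five-membered ring and the point of attachment named in the group, and this single pair cannot divide the step between the two. No measured property shown here bears on the origin of the step.

From the compounds shown here alone, whether the loss follows the point of attachment or the added ring nitrogen remains open, and a 1-methyl-1H-indol-6-yl or 1-methyl-1H-indazol-5-yl group at this place would separate the two. Going by these compounds alone, the value of compound 1, > 10000 nM, is a limit and not a number, and no step involving it can be read.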